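A few compounds are considered here, and "the series" means these few. Any claim that something is new, unique, unknown or untested is made for them only; others in the source may bear on it.

Compound 1, `COc1ccc(/C=C2/SC(N3CCC[C@H]3C(=O)Nc3ccc4ncnc(Nc5cccc(Cl)c5)c4c3)=NC2=O)cc1`, gives 31700 nM in a functional assay on A549 cells (Homo sapiens) for antiproliferative activity, read by MTT assay; on this read-out higher numbers stand for weaker inhibition and lower numbers for stronger inhibition.
Compound 2, `O=C1N=C(N2CCC[C@H]2C(=O)Nc2ccc3ncnc(Nc4cccc(Cl)c4)c3c2)S/C1=C/c1cccc(Cl)c1`, reaches only the limit of > 50000 nM in this assay.
Compound 3, `O=C1N=C(N2CCC[C@H]2C(=O)Nc2ccc3ncnc(Nc4cccc(Cl)c4)c3c2)S/C1=C/c1ccc(-c2ccccc2)cc1`, gives 24200 nM in this assay.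

Compound 3 holds the lowest of the two numbers, but its nearest neighbour is compound 1, and the step of a 1.3-fold lower number from compound 1 to compound 3 (0.12 log units; within the scatter) is within the scatter, so the two cannot be ranked. Compound 4, `O=C1N=C(N2CCC[C@H]2C(=O)Nc2ccc3ncnc(Nc4cccc(Cl)c4)c3c2)S/C1=C/c1cccc(Br)n1`, differs from compound 3 by 6-bromopyridin-2-yl in place of 4-phenylphenyl on a double-bonded chain carbon bound to a double-bonded ring carbon.

Going by the values given here, two measured steps bear on this change. The step of an at least 1.5-fold higher number from compound 1 to compound 2 (0.19 log units; that floor lies within the scatter) shows that a halogenated phenyl in this position ends at the limit described by the limit of > 50000 nM in this assay, at which 1 of the 3 values shown sits. The step of an at least 2.0-fold lower number from compound 2 to compound 3 (0.31 log units; beyond the scatter) shows the same contrast from the other side: the 4-phenylphenyl compound 3 gives a number, the 3-chlorophenyl compound 2 only a limit. Compound 4 carries a halogenated, smaller aromatic ring again, so a higher number, a 1.9-fold higher number from compound 3 to compound 4 (0.27 log units; within the scatter), is expected in this assay, with a real chance that only a limit is reported.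

Compound 4 is therefore expected to give about 45000 nM, between 20000 nM and 120000 nM, in this assay.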

Compound 4, half-maximal inhibitory concentration: 3100 nM
Compound 4: middle estimate off by 15-fold (1.16 log units), on the high side; measured number outside the range, below it.
By their numbers in this assay, from the lowest: compound 4; then compounds 3 and 1 (each within the scatter of the next). At a limit, above all of these: compound 2.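

Before this result, the earlier compounds at this position gave either numbers within the scatter of each other or a limit, and a halogenated aromatic ring showed no sign of lowering the number. The 6-bromopyridin-2-yl group changes that picture, with a 10-fold lower number from compound 1 to compound 4 (1.01 log units; beyond the scatter) and a 7.8-fold lower number from compound 3 to compound 4 (0.89 log units; beyond the scatter) in this assay. The comparison with the 3-chlorophenyl group gives an at least 16-fold lower number from compound 2 to compound 4 (1.20 log units; beyond the scatter), so among these compounds a single halogen-bearing aromatic ring is not tied to weak inhibition, and the two rings of 4-phenylphenyl are not needed for the lowest number, although compound 2 remains a limit and not a number: the limit of > 50000 nM in this assay, at which 1 of the 4 values shown sits.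

The compounds shown cannot separate the part played by the ring nitrogen from that of the bromine, as the group brings both at once and a plain pyridin-2-yl or a 6-chloropyridin-2-yl would be needed to tell them apart. From the compounds shown here alone, it also stays open whether the bromine can give way to another group on the same ring, such as an amine or a methoxy group, with the number staying this low.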